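Alkyl at the ring carbon: isopropyl against methyl

The source may report more compounds than this note shows. Statements on the series, on what has been measured and on what is new or still open speak of the compounds shown alone.

Of the compounds shown here, two have been measured. Compound 1 `CCc1ccccc1-n1ncc(C(=O)Nc2ccc3ccccc3n2)c1C` gives 9700 nM in a functional assay on SW480 cells (Homo sapiens) for inhibition; on this read-out lower numbers stand for stronger inhibition of growth and higher numbers for weaker inhibition of growth. Compound 2 `CC(C)c1c(C(=O)Nc2ccc3ccccc3n2)cnn1-c1ccccc1` gives 17300 nM in this assay and stands at the highest of the two numbers, but its gap to compound 1 lies within the scatter, so the two cannot be ordered. Compound 3 `Cc1c(C(=O)Nc2ccc3ccccc3n2)cnn1-c1ccccc1` is not yet measured. It differs from compound 2 in one place: methyl in place of isopropyl on an aromatic carbon. Within the data shown here, no step between measured compounds covers this change on its own, since compound 1 also carries a different group on the phenyl. Compound 1 does bear a methyl on its core rather than isopropyl, and its value of 9700 nM sits close to that of compound 2, so no shift beyond the scatter is expected in this assay. The step of a 1.4-fold lower number from compound 2 to compound 3 (0.16 log units; within the scatter) is expected to be small. Compound 3 is estimated at 12000 nM, within a range of 5000 nM to 30000 nM.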

Compound 3, concentration for 50% growth inhibition: 23900 nM
The estimate for compound 3 lay 2.0-fold (0.30 log units) below the measured number, and the stated range covers the measured number.
By their numbers in this assay, from the lowest: compounds 1, 2 and 3 (each within the scatter of the next, the first and the last beyond it).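

With methyl in place of isopropyl on the aromatic carbon of the five-membered ring, this assay shows a 1.4-fold higher number from compound 2 to compound 3 (0.14 log units; within the scatter), so the two alkyl groups cannot be told apart at this position. Among these compounds, the only step beyond the scatter lies in the other place: with hydrogen in place of ethyl on an aromatic carbon, the series shows a 2.5-fold higher number from compound 1 to compound 3 (0.39 log units; beyond the scatter), a modest weakening of growth inhibition that marks the ethyl group as the one difference readable so far. Nothing available bears on the reason for either step.

Open, going by these compounds, is whether this position accepts anything other than a small alkyl group, such as an amine, a carboxylic acid or a longer chain. Also open, on these data alone, is whether the ethyl step holds with isopropyl on the core.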